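The source may hold more compounds than are shown below. What is called first, only, known or untested is meant among the compounds shown, and "the series" means these compounds.

Values measured in a functional assay on HCT-116 cells (Homo sapiens) for cytotoxicity, read by MTT assay, with a stated time of 48 h, in the presence of a further agent that is not named here (a higher number here means that more compound is needed for the effect, a lower number that less compound is needed), so far:
- compound 1 `CCCc1cc(NNC(=O)Nc2cc(Cl)nc(Cl)c2)nc2c1c(C)nn2C` at 72200 nM
- compound 2 `Cc1nn(C)c2nc(NNC(=O)Nc3cc(Cl)nc(Cl)c3)cc(C3CCCCC3)c12` at 38000 nM

Going by the values given here, compound 2 stands level, within the scatter, with the only other number (a 1.9-fold lower number from compound 1 to compound 2 (0.28 log units; within the scatter)). Next is compound 3 `Cc1nn(C)c2nc(NNC(=O)Nc3cc(Cl)nc(Cl)c3)cc(-c3ccccc3)c12` with phenyl in place of cyclohexyl on an aromatic carbon as its difference: phenyl in place of cyclohexyl on an aromatic carbon, opposite the ring nitrogen. Only the change of cyclohexyl in place of propyl bears on it, made at the same place, and its size (a 1.9-fold lower number from compound 1 to compound 2 (0.28 log units; within the scatter)) shows no move beyond the scatter there so far. No phenyl at this place has been measured, so the expectation is loose. In this assay no step beyond the scatter is expected, and the estimated step is small (a 1.1-fold higher number from compound 2 to compound 3 (0.02 log units; within the scatter)). Compound 3 is expected at 40000 nM with a range from 15000 nM to 100000 nM as estimated.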

Compound 3, half-maximal effective concentration: 80000 nM
Estimate against measurement, compound 3: 2.0-fold (0.30 log units) below, and the stated range covers the measured number.
By their numbers in this assay, from the lowest: compounds 2, 1 and 3 (each within the scatter of the next, the first and the last beyond it).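

In this assay, this position gives its first step beyond the scatter: with phenyl in place of cyclohexyl, both six-membered rings of carbon only, the result is a 2.1-fold higher number from compound 2 to compound 3 (0.32 log units; beyond the scatter). The aromatic and non-aromatic rings can therefore be told apart here, though only modestly and on this single pair, while phenyl in place of propyl stays level, with a 1.1-fold higher number from compound 1 to compound 3 (0.04 log units; within the scatter). Nothing available explains why the two rings differ.

Open, from the compounds shown here alone, is whether a pyridyl ring, an amine or a methoxy group on this aromatic carbon would move the number further than the small steps seen so far. Also open, going by these compounds, is whether the difference between phenyl and cyclohexyl holds when the rest of the shared core carries other groups.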